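A few compounds are considered here, and "the series" means these few. Any claim that something is new, unique, unknown or untested is made for them only; others in the source may bear on it.

Measured compounds:
Compound 2, `COc1cc2c(Oc3ccc(NC(=O)NN4C(=O)CSC4c4cccc(F)c4F)cc3)ccnc2cc1OC1CCN(C(=O)NC(C)C)CC1`, gives 790 nM in a functional assay on HT-29 cells (Homo sapiens) for inhibition, read by MTT assay; a lower number here means a stronger inhibitor, a higher number a weaker inhibitor.
Compound 1, `COc1cc2c(Oc3ccc(NC(=O)NN4C(=O)CSC4c4ccc(F)cc4)cc3)ccnc2cc1OC1CCN(C(=O)NCc2ccccc2)CC1`, gives 6600 nM in this assay.

Compound 2 stands at the lower of the two numbers. Its nearest neighbour is compound 1, whose number is higher by a margin that lies beyond the usual scatter of repeated measurements. For the measured compounds named here, compound 1 and compound 2 differ from one another in more than one place, so their two values show only that the pair is separated, not which change accounts for it.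

Compound 3, `COc1cc2c(Oc3ccc(NC(=O)NN4C(=O)CSC4c4c(F)cc(F)cc4F)cc3)ccnc2cc1OC1CCN(C(=O)NC(C)C)CC1`, has not yet been measured. It differs from compound 2 in a single place: 2,4,6-trifluorophenyl in place of 2,3-difluorophenyl on a saturated ring carbon. Going by the values given here, there is no measured pair in this set that isolates a change of this kind, so the size and direction of the step can only be guessed. With nothing in the data pointing either way, compound 3 is expected to land close to compound 2, with a step from compound 2 to compound 3 of a 1.3-fold higher number from compound 2 to compound 3 (0.10 log units; within the scatter), which is taken to be none beyond the scatter. In this assay compound 3 is therefore estimated at 1000 nM, within a range of 300 nM to 3500 nM.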

Compound 3, half-maximal inhibitory concentration: 910 nM
Compound 3: the middle estimate sits 1.1-fold (0.04 log units) above what was measured; the measured number falls inside the stated range.
By their numbers in this assay, from the lowest: compounds 2 and 3 (each within the scatter of the next); then compound 1.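

In this assay, for the compounds shown here, the exchange of 2,3-difluorophenyl for 2,4,6-trifluorophenyl on a saturated ring carbon of the five-membered non-aromatic ring with 1 nitrogen and 1 sulfur gives a 1.2-fold higher number from compound 2 to compound 3 (0.06 log units; within the scatter) and is the first step in this set that isolates a change at one place. It shows that this position accepts a third fluorine and a different arrangement of the fluorines on the phenyl ring with no step beyond the scatter, so compound 2 and compound 3 cannot be told apart in this read-out. Nothing measured here bears on why the two groups read alike.

On these data alone, both groups are fluorinated phenyl rings, so it remains open whether the same tolerance would hold for an unsubstituted phenyl, a chlorophenyl, a methoxyphenyl, a pyridine ring or a small alkyl chain on this carbon. As far as these compounds go, it is also open whether a step of this size would persist if the urea end of the molecule carried something other than the group shared by compound 2 and compound 3, such as a morpholine or a carboxylic acid.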